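The source may report more compounds than this note shows. Statements on the series, on what has been measured and on what is new or still open speak of the compounds shown alone.

Going by the values given here, in a functional assay on K562 cells (Homo sapiens) for antiproliferative activity, read by MTT assay, with a stated time of 24 h (a lower number here means a stronger inhibitor, a higher number a weaker inhibitor), compound 1 `COc1ccc(C(=O)/C=C/c2ccc(N(C)C)cc2)c2c1C=CC(C)(C)O2` gives 3500 nM, the higher of the two actual numbers so far, since compound 2 `CCN(CC)c1ccc(/C=C/C(=O)c2ccc(OC)c3c2OC(C)(C)C=C3)cc1` gives 790 nM. Compound 3 `COc1ccc(C(=O)/C=C/c2ccc(-n3ccnc3)cc2)c2c1C=CC(C)(C)O2` reports only a limit of the assay, > 10000 nM. Compound 4 `COc1ccc(C(=O)/C=C/c2ccsc2)c2c1C=CC(C)(C)O2` has not yet been measured. It keeps the core of compound 1 and changes the group on a double-bonded chain carbon bound to a double-bonded chain carbon: thiophen-3-yl in place of 4-(dimethylamino)phenyl on a double-bonded chain carbon bound to a double-bonded chain carbon. The measured steps bear on this only indirectly, as each alters just the group on an aromatic carbon. Diethylamino in place of dimethylamino gave a modest 4.4-fold lower number from compound 1 to compound 2 (0.65 log units; beyond the scatter). 1H-imidazol-1-yl in place of dimethylamino gave an at least 2.8-fold higher number from compound 1 to compound 3 (0.45 log units; beyond the scatter), and in place of diethylamino a large at least 12-fold higher number from compound 2 to compound 3 (1.10 log units; beyond the scatter). Among the compounds with values here, compound 4 also lacks the amino group, and compound 3, the one measured compound without it, moved upward in an at least 2.8-fold higher number from compound 1 to compound 3 (0.45 log units; beyond the scatter). A modest rise, toward a weaker inhibitor, is expected here, estimated as a 2.1-fold higher number from compound 1 to compound 4 (0.33 log units; beyond the scatter). For compound 4 the expected value is 7500 nM, with an estimated range from 2500 nM to 10000 nM.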

Compound 4, half-maximal inhibitory concentration: > 10000 nM
Compound 4 gave a limit, no number; the forecaster's own chance of this, stated with the estimate: 40%; at least 1.3-fold (0.12 log units) between middle value and limit.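

In this assay compound 4 gives > 10000 nM, which is a limit of the assay and not a number. The earlier steps shown here all changed a group on an aromatic carbon, whereas this one replaces the whole 4-(dimethylamino)phenyl with thiophen-3-yl on a double-bonded chain carbon bound to a double-bonded chain carbon, giving an at least 2.8-fold higher number from compound 1 to compound 4 (0.45 log units; beyond the scatter), so activity at this position does not survive the swap to this five-membered ring. Only compounds with dimethylamino or diethylamino give actual numbers here, but the full size of the new step cannot be read, because it ends at a limit: the limit of > 10000 nM in this assay, at which 2 of the 4 values shown sit.

Still open, on these data alone, is whether the loss follows the change of ring or the missing amino group, since this change alters both at once. A plain phenyl group at this place, or a thiophen-3-yl ring carrying a dimethylamino group, would separate the two.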